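A few compounds are considered here, and "the series" means these few. Any claim that something is new, unique, unknown or untested is made for them only; others in the source may bear on it.

Measured compounds in an assay on LM cells for displacement of a labelled ligand from Neuropeptide Y receptor type 5 (Homo sapiens); a higher number here means a weaker inhibitor, a lower number a stronger inhibitor:
- compound 1, `Fc1ccc(C2(c3ccc(F)cc3)CNC(c3cccc(F)c3)=N2)cc1` — compound 1 gives 10 nM
- compound 2, `O=Cc1cccc(C2=NC(c3ccc(F)cc3)(c3ccc(F)cc3)CN2)c1` — compound 2 gives 8.7 nM

Within the data shown here, compound 2 stands alongside compound 1 on these numbers: the only step that separates them, a 1.1-fold lower number from compound 1 to compound 2 (0.06 log units; within the scatter), is within the scatter, so neither can be called the stronger binder. That step swapped a fluoro for a formyl on one aromatic ring, a change the assay hardly registered.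

Compound 3, `CN(C)c1cccc(C2=NC(c3ccc(F)cc3)(c3ccc(F)cc3)CN2)c1`, takes the same ring one move further: dimethylamino in place of formyl on an aromatic carbon. Among the measured compounds shown here, the one measured step that bears on this position, from compound 1 to compound 2, was within the scatter, so a further change there is expected to stay small as well; no step beyond the scatter in either direction is expected, and a 1.1-fold higher number from compound 2 to compound 3 (0.06 log units; within the scatter) is the estimated shift. Compound 3 is therefore estimated at 10 nM, with a range from 3 nM to 35 nM.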

Compound 3, half-maximal inhibitory concentration: > 1000 nM
Compound 3: only a limit was reported (the forecaster's own chance of this, stated with the estimate: 3%); middle value at least 100-fold (2.00 log units) away from the limit.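

In this assay, this position proves far from indifferent: dimethylamino in place of formyl gives an at least 110-fold higher number from compound 2 to compound 3 (2.06 log units; beyond the scatter), and dimethylamino in place of fluoro gives an at least 100-fold higher number from compound 1 to compound 3 (2.00 log units; beyond the scatter). The earlier swap of fluoro for formyl stayed within the scatter, but that did not mean any group is accepted here, since compound 3 is clearly a weaker inhibitor than either earlier compound. Compound 3 carries a limit of the assay rather than a number: the limit of > 1000 nM in this assay, at which 1 of the 3 values shown sits.

The compounds shown leave open whether a plain amine, a methylamino group or a methoxy group at this same place would keep binding, as fluoro and formyl do, or lose it, as dimethylamino does. They also cannot tell why dimethylamino behaves so differently from the other two groups.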